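Acetyl to dimethylamino: compound 1 to compound 4

A few compounds are considered here, and "the series" means these few. Any claim that something is new, unique, unknown or untested is made for them only; others in the source may bear on it.

Of the compounds shown here, three of the shared core have been tested in a functional assay on M14 cells (Homo sapiens) for cytotoxicity, read by sulforhodamine B assay, with a stated time of 48 h, tested at 0.01 uM; a higher number here means a weaker effect of the compound at the concentration tested, a lower number a stronger effect. Compound 1 `COc1cc(C)cc(-c2c(-c3ccnc(-c4ccc(C(C)=O)cc4)c3)cnn2CC#N)c1` gives 86% in this assay. Compound 2 `COc1cc(C)cc(-c2nn(CC#N)cc2-c2ccc(-c3cccc(C(C)=O)c3)nc2)c1` gives 93%, and compound 3 `Cc1cc(O)cc(-c2nn(CC#N)cc2-c2ccnc(-c3ccc(Oc4ccccc4)cc3)c2)c1` gives 96%. Compound 1 has the lowest number of the three, but its gaps to compound 2 and to compound 3 both lie within the scatter, so no order among the three is established; each shows only a weak effect at the concentration tested.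

Compound 4 `COc1cc(C)cc(-c2c(-c3ccnc(-c4ccc(N(C)C)cc4)c3)cnn2CC#N)c1` differs from compound 1 in one place: dimethylamino in place of acetyl on an aromatic carbon. Cut one bond further out, the change reads 4-acetylphenyl to 4-(dimethylamino)phenyl. Among the measured compounds shown here, no pair of measured compounds shows this change, so the numbers give no size for it. With the three measured values high and close together, the expected step of a number 2 percentage points higher from compound 1 to compound 4 (within the scatter) stays within the scatter, in no fixed direction. For compound 4 the estimate in this assay is 88%, between 74% and 100%.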

Compound 4, a percentage reported as activity, at one concentration (the size of the read-out at that concentration, not a potency): -19%
Estimate against measurement, compound 4: 107 percentage points above; measured number below the stated range.
By their numbers in this assay, from the lowest: compound 4; then compounds 1, 2 and 3 (each within the scatter of the next).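

In this assay, among the compounds shown here, dimethylamino in place of acetyl gives a number 105 percentage points lower from compound 1 to compound 4 (beyond the scatter), so the substituent at this place, para to a large group, can decide the outcome, which the three close values of the earlier compounds could not show. Leaving and entering groups match in heavy-atom count, hydrogen-bond donors and hydrogen-bond acceptors, so these counts do not separate them; they differ in the acetyl oxygen and its double bond against the dimethylamino nitrogen. Nothing at hand accounts for the size of this step.

A primary amine or a methoxy group at this place would test whether the gain needs dimethylamino itself. Going by these compounds, the step rests on a single pair of compounds, so how far it holds elsewhere remains open.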